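This account rests on a few compounds, and the source may have more. Where it says the series, first, only, none or still open, it means among the compounds named here.

In an ADME assay on HEK293 cells (Homo sapiens) for cytotoxicity, with a stated time of 72 h (a lower number here means that less compound is needed, a higher number that more compound is needed for the effect), compound 1 (`C=C[C@@](C)(/C=C/c1ccc(OC)cc1)CCC=C(C)C`) is reported only as a limit, > 36600 nM. Compound 2 (`C=C[C@@](C)(/C=C/c1ccc(Nc2ccc(F)c(F)c2)cc1)CCC=C(C)C`) carries (3,4-difluorophenyl)amino in place of methoxy on an aromatic carbon, and it too is reported only as a limit, > 36600 nM. Compound 2 therefore stands at the limit of > 36600 nM in this assay, at which 2 of the 2 values shown sit, with no number to place it. Compound 3 (`C=C[C@@](C)(/C=C/c1ccc(Nc2ccc(Cl)c(F)c2)cc1)CCC=C(C)C`) has chloro in place of fluoro on an aromatic carbon, para to a large group: chloro in place of fluoro on an aromatic carbon. Going by the values given here, the only measured step, a step that the two limits leave unreadable from compound 1 to compound 2, gives no size to carry over, so no shift beyond the scatter is expected in this assay. The expected step is a number no higher from compound 2 to compound 3 (the limit leaves the size open), and a report as a limit is again likely. For compound 3 the estimated value is 36600 nM, with an expected range from 15000 nM to 70000 nM.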

Compound 3, half-maximal effective concentration: > 36600 nM
Compound 3: no number, only a limit; the forecaster's own chance of this, stated with the estimate: 80%; the middle value sits exactly at the limit.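

Compound 3 is likewise reported only as a limit in this assay, so neither its step from compound 2 nor its step from compound 1 can be read: the limit of > 36600 nM in this assay, at which 3 of the 3 values shown sit. The compounds shown leave open how far each lies beyond that limit, and whether chloro in place of fluoro alters the value at all.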